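The source may report more compounds than this note shows. Statements on the series, on what has been measured and on what is new or still open speak of the compounds shown alone.

Compounds measured so far in a functional assay on DU-145 cells (Homo sapiens) for cytotoxicity, read by sulforhodamine B assay, with a stated time of 48 h; on this read-out higher numbers stand for weaker inhibition of growth and lower numbers for stronger inhibition of growth:

compound 1 `CN1CCN(c2nc(Nc3ccc(C#N)c(C(F)(F)F)c3)nc(Oc3ccnc4ccccc34)n2)CC1` — 51200 nM
compound 2 `COc1ccc(N2CCN(c3nc(Nc4ccc(C#N)c(C(F)(F)F)c4)nc(Oc4ccnc5ccccc45)n3)CC2)cc1` — a limit, > 100000 nM
compound 3 `N#Cc1ccc(Nc2nc(Oc3ccnc4ccccc34)nc(N3CCN(Cc4ccccc4)CC3)n2)cc1C(F)(F)F` — a limit, > 100000 nM

Among the compounds with values here, compound 1 stands alone as the one number in this assay; the other two values are the limit of > 100000 nM in this assay, at which 2 of the 3 values shown sit, so only floors are known for compounds 2 and 3. The steps run an at least 1.9-fold higher number from compound 1 to compound 2 (0.29 log units; that floor lies within the scatter) and an at least 1.9-fold higher number from compound 1 to compound 3 (0.29 log units; that floor lies within the scatter), while a step that the two limits leave unreadable from compound 2 to compound 3.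

Compound 4 `N#Cc1ccc(Nc2nc(Oc3ccnc4ccccc34)nc(N3CCCCC3)n2)cc1C(F)(F)F` differs from compound 1 by piperidin-1-yl in place of 4-methylpiperazin-1-yl on an aromatic carbon. Neither measured step bears on this change directly: both alter the group carried on the amine nitrogen of the ring, whereas compound 4 removes that nitrogen and keeps only the saturated carbocycle portion of the ring. The two measured steps show that changes at this ring in this series have so far only lost ground or left the value unreadable, and nothing shows a gain.

The expected step is therefore a 1.4-fold higher number from compound 1 to compound 4 (0.14 log units; within the scatter), a small loss or no change beyond the scatter, with a real chance that only a limit is returned. For compound 4 the estimate is 70000 nM, within 25000 nM to 200000 nM.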

Compound 4, concentration for 50% growth inhibition: 94900 nM
Estimate against measurement, compound 4: 1.4-fold (0.13 log units) below, and the stated range covers the measured number.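

In this assay the exchange of 4-methylpiperazin-1-yl for piperidin-1-yl on this aromatic carbon, opposite the ring nitrogen, gives a 1.9-fold higher number from compound 1 to compound 4 (0.27 log units; within the scatter) and so no step beyond the scatter. Unlike the changes on the amine nitrogen of the ring, which returned only floors, this change yields a readable step, and the value of compound 1 is not shown to depend on that nitrogen. Compound 2 and compound 3 remain limits, not numbers, and the step between them cannot be read: the limit of > 100000 nM in this assay, at which 2 of the 4 values shown sit.

Going by these compounds, whether any group at this position moves the value beyond the scatter remains open. Also open, on these data alone, is how morpholin-4-yl, a dimethylamino group or a primary amine on this carbon would compare with 4-methylpiperazin-1-yl in compound 1.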